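This account rests on a few compounds, and the source may have more. Where it says the series, first, only, none or still open, it means among the compounds named here.

Measured so far:
Compound 1 `Cc1ccc(C(=O)CCN2CCN(c3ccc(F)cc3)CC2)cc1`: 55400 nM
Compound 2 `O=C(CCN1CCN(c2ccc(F)cc2)CC1)c1ccc(F)c(Br)c1`: 352000 nM

In an ADME assay on Vero cells (Chlorocebus sabaeus) for cytotoxicity, read by resazurin assay, with a stated time of 72 h (on this read-out higher numbers stand for weaker inhibition and lower numbers for stronger inhibition), compound 2 holds the higher of the two numbers at 352000 nM, and compound 1 sits lower at 55400 nM. Next comes compound 3 `O=C(CCN1CCN(c2ccc(F)cc2)CC1)c1ccc(F)c(Cl)c1`, which differs from compound 2 in a single place: chloro in place of bromo on an aromatic carbon. Chloro takes the place of bromo on an aromatic carbon, ortho to a fluoro group and meta to a large group, giving 3-chloro-4-fluorophenyl. Among the compounds with values here, only one measured step bears on this: a 6.4-fold higher number from compound 1 to compound 2 (0.80 log units; beyond the scatter). That modest step, beyond the scatter, replaced 4-methylphenyl with 3-bromo-4-fluorophenyl, a larger swap than the present one. Within the data shown here, no measured pair isolates bromo against chloro, so the guide is indirect. A smaller step is therefore expected, most likely within the scatter, with a slight lean towards a lower number. The expected change is a 1.6-fold lower number from compound 2 to compound 3 (0.20 log units; within the scatter). The estimate for compound 3 is 220000 nM, with an expected range of 90000 nM to 450000 nM.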

Compound 3, half-maximal inhibitory concentration: 185000 nM
Estimate against measurement, compound 3: 1.2-fold (0.08 log units) above; the range from low to high includes it.
By their numbers in this assay, from the lowest: compound 1; then compounds 3 and 2 (each within the scatter of the next).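

In this assay, chloro in place of bromo gives a 1.9-fold lower number from compound 2 to compound 3 (0.28 log units; within the scatter), so at this aromatic carbon, ortho to a fluoro group and meta to a large group, the two halogens cannot be told apart on this read-out. Within the data shown here, the second step, a 3.3-fold higher number from compound 1 to compound 3 (0.52 log units; beyond the scatter), shows that the shift away from compound 1 is not tied to bromo: with chloro at the same carbon, the number still stands higher than for the 4-methylphenyl compound, beyond the scatter, though only three compounds support this reading. Nothing measured here offers a reason for either step.

The compounds shown leave open how far this tolerance extends, for instance whether a methoxy, trifluoromethyl or nitrile group at the same carbon would stay level with chloro and bromo, or whether an amine or a carboxylic acid there would move the number well away from them. They also leave open how much of the step from the 4-methylphenyl compound belongs to the halogen and how much to the fluoro group, since these two groups always enter together in the compounds shown.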